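Extending the propargyl urea chain into an acrylate ester

The compounds below may be only part of what the source reports. "The series", "measured", "known", "first", "only" and "open" are said of these compounds alone.

Three ureas sharing one core have been measured in a functional assay on A-431 cells (Homo sapiens) for antiproliferative activity, read by sulforhodamine B assay, with a stated time of 72 h; on this read-out lower numbers stand for stronger inhibition and higher numbers for weaker inhibition. Compound 3 `C#CCNC(=O)Nc1cc2c(Nc3ccc(F)c(Cl)c3)ncnc2cc1O[C@H]1CCOC1` gives 3730 nM and stands second highest of the three numbers. Its nearest neighbour is compound 2 `O=C(Nc1cc2c(Nc3ccc(F)c(Cl)c3)ncnc2cc1O[C@H]1CCOC1)N1CCC(F)(F)CC1`, which gives 1860 nM; the pair differ by a 2.0-fold higher number from compound 2 to compound 3 (0.30 log units; within the scatter), within the scatter. Furthest from it is compound 1 `COC(CCNC(=O)Nc1cc2c(Nc3ccc(F)c(Cl)c3)ncnc2cc1O[C@H]1CCOC1)OC`, which gives 22000 nM; here the separation is a 5.9-fold lower number from compound 1 to compound 3 (0.77 log units; beyond the scatter), beyond the scatter.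

Compound 4 `COC(=O)/C=C/CNC(=O)Nc1cc2c(Nc3ccc(F)c(Cl)c3)ncnc2cc1O[C@H]1CCOC1` is not yet measured. Relative to compound 3 the change is 2-(methoxycarbonyl)ethenyl in place of ethynyl on a saturated chain carbon bound to an amide-type nitrogen. The step that bears most directly on it is the one at the same place, where the shorter ethynyl chain gave a 5.9-fold lower number from compound 1 to compound 3 (0.77 log units; beyond the scatter), so a longer, oxygen-bearing chain on this carbon went with a modest loss. The step of a 2.0-fold higher number from compound 2 to compound 3 (0.30 log units; within the scatter) shows that exchanging the whole urea substituent can also leave the number essentially unchanged. Compound 4 is therefore expected to show a 1.6-fold higher number from compound 3 to compound 4 (0.21 log units; within the scatter), a weakening of modest size and no more, given that compound 1 with its longer chain reached only 22000 nM. The estimate for compound 4 is 6000 nM, with a range from 1800 nM to 20000 nM.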

Compound 4, half-maximal inhibitory concentration: 1410 nM
Compound 4: the middle estimate sits 4.3-fold (0.63 log units) above what was measured; the measured number lies below the stated range.
By their numbers in this assay, from the lowest: compounds 4, 2 and 3 (each within the scatter of the next, the first and the last beyond it); then compound 1.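

In this assay, the exchange of ethynyl for 2-(methoxycarbonyl)ethenyl on the saturated chain carbon bound to an amide-type nitrogen gives a 2.6-fold lower number from compound 3 to compound 4 (0.42 log units; beyond the scatter) and so adds a case in which the larger group goes with the lower number, where compound 1 alone had suggested the opposite. Compound 1 and compound 4 both carry oxygen in the chain at this place, yet the change from 2,2-dimethoxyethyl to 2-(methoxycarbonyl)ethenyl gives a 16-fold lower number from compound 1 to compound 4 (1.19 log units; beyond the scatter) and shows that the presence of oxygen in a longer group does not by itself set the number. The exchange of 4,4-difluoropiperidin-1-yl for (3-(methoxycarbonyl)prop-2-en-1-yl)amino on the carbonyl carbon gives a 1.3-fold lower number from compound 2 to compound 4 (0.12 log units; within the scatter) and leaves these two ureas level within the scatter.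

The compounds shown do not separate the contribution of the double bond from that of the methyl ester, since none carries the carboxylic acid, a primary amide or the saturated propyl ester chain at this place. No available evidence explains the differences among these ureas.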